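Swapping an amine for a ketone on a cytotoxic scaffold

The source may report more compounds than this note shows. Statements on the series, on what has been measured and on what is new or still open speak of the compounds shown alone.

Three compounds sharing one core were tested in a functional assay on K562 cells (Homo sapiens) for cytotoxicity, read by sulforhodamine B assay, with a stated time of 48 h, tested at 100 nM; a higher number here means a weaker effect of the compound at the concentration tested, a lower number a stronger effect. Compound 1 `COc1cc(C)cc(-c2c(-c3ccnc(-c4ccc(N(C)C)cc4)c3)cnn2CC#N)c1` gives 7%, the lowest of the three numbers and thus the strongest effect seen. Compound 2 `COc1cc(C)cc(-c2nn(CC#N)cc2-c2ccc(-c3cccc(C(C)=O)c3)nc2)c1` gives 27%, a number beyond the scatter above compound 1, and compound 3 `Cc1cc(O)cc(-c2nn(CC#N)cc2-c2ccnc(-c3ccc(N(C)C)cc3)c2)c1` gives 80%, the highest number and the weakest effect of the set.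

The step of interest leads from compound 1 to compound 4 `COc1cc(C)cc(-c2c(-c3ccnc(-c4ccc(C(C)=O)cc4)c3)cnn2CC#N)c1`, which has not yet been measured. The change is acetyl in place of dimethylamino on an aromatic carbon; the group sits on an aromatic carbon of a six-membered aromatic ring of carbon only, para to a large group.

Within the data shown here, with no measured pair showing this exact change, the expectation rests on compound 2, which also carries an acetyl group. Compound 4 is expected to show a weaker effect than compound 1, because compound 2 gives 27% in this assay. The expected step is a number 23 percentage points higher from compound 1 to compound 4 (beyond the scatter), in the direction of a higher number. The estimate for compound 4 is 30%, with a range from 10% to 60%.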

Compound 4, a percentage reported as activity, at one concentration (the size of the read-out at that concentration, not a potency): 47%
The estimate for compound 4 lay 17 percentage points below the measured number; the measured number falls inside the stated range.
By their numbers in this assay, from the lowest: compound 1; then compound 2; then compound 4; then compound 3.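

Among these compounds, compound 1 and compound 4 differ in one place only, so this pair gives the first direct reading of this position: in this assay, acetyl in place of dimethylamino gives a number 40 percentage points higher from compound 1 to compound 4 (beyond the scatter), a large loss of effect at the concentration tested. The two groups match in their counts of heavy atoms and hydrogen-bond acceptors, so those counts alone do not separate the two results. No measurement shown here explains the size of this step.

Only these two groups are seen at this position, which leaves open how a diethylamino group, a primary amine or a carboxylic acid would read there. As far as these compounds go, a single pair carries this change, so whether the step would hold on another version of the shared core also remains open.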